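Pyridinyl Swap on the Shared Core in an Adenosine Antagonist Series

The source may hold more compounds than are shown below. What is called first, only, known or untested is meant among the compounds shown, and "the series" means these compounds.

Compound 1 `N#Cc1cccc(-c2nc(N)c3cc(Cc4ccccc4)sc3n2)c1`: 222 nM
Compound 2 `COc1cccc(-c2nc(N)c3cc(Cc4ccccc4)sc3n2)c1`: 266 nM
Compound 3 `Nc1nc(-c2ccccn2)nc2sc(Cc3ccccc3)cc12`: 3710 nM

In a functional assay on CHO-K1 cells for antagonist activity at adenosine receptor A1 (Homo sapiens), read by a beta-galactosidase reporter and cAMP accumulation, with stated times of 15 min and 6 h (on this read-out higher numbers stand for weaker inhibition and lower numbers for stronger inhibition), compound 3 gives the highest of the three numbers; against compound 2 its step runs as a 14-fold higher number from compound 2 to compound 3 (1.14 log units; beyond the scatter) and against compound 1 as a 17-fold higher number from compound 1 to compound 3 (1.22 log units; beyond the scatter), both well beyond the scatter. Compounds 1 and 2 differ from each other by a 1.2-fold higher number from compound 1 to compound 2 (0.08 log units; within the scatter), which lies within the scatter. The unmeasured compound 4 `Nc1nc(-c2ccncc2)nc2sc(Cc3ccccc3)cc12` keeps the shared core and differs from compound 3 only in the change (pyridin-4-yl in place of pyridin-2-yl on an aromatic carbon). Going by the values given here, no measured step moves one pyridinyl to another, so the size of this step cannot be read off directly; the two large steps from the substituted phenyl rings to compound 3 show only how far the pyridin-2-yl analog sits from the rest. Compound 4 is therefore expected to land between the phenyl analogs and compound 3, with a wide range, so that compound 4 is estimated at 1500 nM in this assay, spanning 300 nM to 8000 nM. For compound 4 the expected step is a 2.5-fold lower number from compound 3 to compound 4 (0.39 log units; beyond the scatter).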

Compound 4, inhibition constant: 812 nM
The estimate for compound 4 lay 1.8-fold (0.27 log units) above the measured number, and the stated range covers the measured number.
By their numbers in this assay, from the lowest: compounds 1 and 2 (each within the scatter of the next); then compound 4; then compound 3.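

In this assay the swap of pyridin-2-yl for pyridin-4-yl, which keeps the same atoms but joins them differently, gives a 4.6-fold lower number from compound 3 to compound 4 (0.66 log units; beyond the scatter) and shows that the number at this position depends on which pyridinyl group is attached. The wide gap that separated compound 3 from the substituted phenyl analogs therefore does not hold in full for every pyridinyl group on the shared core. Compound 4 still stays apart from those analogs, with a 3.1-fold higher number from compound 2 to compound 4 (0.48 log units; beyond the scatter) and a 3.7-fold higher number from compound 1 to compound 4 (0.56 log units; beyond the scatter) both beyond the scatter.

The compounds shown leave open where pyridin-3-yl would fall, and whether an amine or a methoxy group on the pyridin-4-yl ring would close the remaining gap. Nothing available here accounts for the difference between the two pyridinyl groups.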